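Vinyl in place of methyl on a carbonyl carbon

The compounds below may be only part of what the source reports. "The series", "measured", "known", "first", "only" and "open" are said of these compounds alone.

In a functional assay on NCI-H460 cells (Homo sapiens) for inhibition, read by MTT assay, with a stated time of 72 h (a lower number here means a stronger inhibitor, a higher number a weaker inhibitor), compound 2 (`CC(=O)Nc1cccc(C(=O)/C=C2/C(=O)Nc3ccccc32)c1`) gives 12300 nM and compound 1 (`CCC(=O)Nc1cccc(C(=O)/C=C2/C(=O)Nc3ccccc32)c1`) gives 10300 nM as its value, so the two lie within the scatter of each other. Compound 3 (`C=CC(=O)Nc1cccc(C(=O)/C=C2/C(=O)Nc3ccccc32)c1`) has vinyl in place of methyl on a carbonyl carbon. Among the measured compounds shown here, the only measured step (a 1.2-fold higher number from compound 1 to compound 2 (0.08 log units; within the scatter)) lies within the scatter and involves no double bond, so it is only a weak guide here. A modest move to a lower number is expected (a 2.1-fold lower number from compound 2 to compound 3 (0.31 log units; beyond the scatter)) in this assay for this change. Compound 3 is estimated at 6000 nM (expected range 1800 nM to 14000 nM).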

Compound 3, half-maximal inhibitory concentration: 3200 nM
Compound 3: the middle estimate sits 1.9-fold (0.27 log units) above what was measured; measured number inside the range.
By their numbers in this assay, from the lowest: compound 3; then compounds 1 and 2 (each within the scatter of the next).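

In this assay, the methyl and ethyl compounds had stayed within the scatter of each other, but vinyl on this carbonyl carbon gives a step beyond it: a 3.8-fold lower number from compound 2 to compound 3 (0.58 log units; beyond the scatter), and a 3.2-fold lower number from compound 1 to compound 3 (0.51 log units; beyond the scatter). The second step replaces ethyl, so among these compounds the lower number goes with the double bond and not simply with a chain longer than methyl. Nothing given here explains the change. The compounds shown leave open whether a methyl-substituted vinyl, an ethynyl or a vinyl bearing a dimethylamino group would keep the lower number.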